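The source may hold more compounds than are shown below. What is called first, only, known or untested is meant among the compounds shown, and "the series" means these compounds.

Measured in an assay on isolated protein for inhibition of Leucine-rich repeat serine/threonine-protein kinase 2 variant G2019S (Homo sapiens), read by TR-FRET and LanthaScreen, with stated times of 50 min and 30 min, in the presence of a further agent that is not named here; on this read-out lower numbers stand for stronger inhibition and higher numbers for weaker inhibition:
compound 1, `Cc1nn(C2COC2)cc1Nc1nc(N)c2c(C#N)c(N3CCC[C@H]3C)n(C)c2n1`, gives 25 nM;
compound 2, `CN(C)c1c(C#N)c2c(N)ncnc2n1C`, gives 3760 nM;
compound 3, `Cn1c(NCc2ccccc2)c(C#N)c2c(N)ncnc21`, gives 3530 nM.

Compound 1 has the lowest number of the three; its gaps to compound 2 and to compound 3 both lie beyond the scatter, so on these numbers compound 1 is the strongest inhibitor. Compound 2 and compound 3 lie within the scatter of each other. For the measured compounds named here, no two measured compounds differ in one place only, so no single step has been measured yet. Compound 4, `Cc1nn(C)cc1Nc1nc(N)c2c(C#N)c(N3CCC[C@H]3C)n(C)c2n1`, differs from compound 1 in one place: methyl in place of oxetan-3-yl on an aromatic nitrogen. Nothing measured here speaks to this exchange, and the large pieces shared with compound 1 remain untouched. The step from compound 1 to compound 4 is expected to be a 1.3-fold higher number from compound 1 to compound 4 (0.11 log units; within the scatter), within the scatter, with no clear direction. Compound 4 is estimated at 32 nM, between 10 nM and 100 nM.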

Compound 4, half-maximal inhibitory concentration: 30 nM
Estimate against measurement, compound 4: 1.1-fold (0.03 log units) above; low and high end bracket the measured number.
By their numbers in this assay, from the lowest: compounds 1 and 4 (each within the scatter of the next); then compounds 3 and 2 (each within the scatter of the next).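

In this assay, methyl in place of oxetan-3-yl on the aromatic nitrogen gives a 1.2-fold higher number from compound 1 to compound 4 (0.08 log units; within the scatter), the first single step read at this position. The four-membered ring and its hydrogen-bond acceptor can therefore leave this position with the number staying within the scatter, at least on the core of compound 1. No measurement available here bears on why the two groups read alike. Still open, on these data alone, is how a longer chain, an amine or a carboxylic acid on the same nitrogen would read. Also open, as far as these compounds go, is whether plain hydrogen there would hold the number.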